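The compounds below may be only part of what the source reports. "The series", "measured", "known", "first", "only" and "open" are said of these compounds alone.

Compound 1 `COc1ccc(/C=C/c2cc(OC)cc(OC)c2/C=C/C(=O)c2cc3ccc(Cl)cc3oc2=O)cc1` carries a chloro on the coumarin-type core and gives in an assay on isolated protein for inhibition of Amine oxidase [flavin-containing] A (Homo sapiens), read by fluorescence, with a stated time of 15 min (on this read-out lower numbers stand for stronger inhibition and higher numbers for weaker inhibition), a value of > 60000 nM, which is a limit of this assay and not a number; compound 1 thus stands at the limit of > 60000 nM in this assay, at which 1 of the 2 values shown sits. Compound 2 `CCOc1cccc2cc(C(=O)/C=C/c3c(/C=C/c4ccc(OC)cc4)cc(OC)cc3OC)c(=O)oc12`, with a different core substitution, gives in this assay 3200 nM. Compound 3 `COc1ccc(/C=C/c2cc(OC)cc(OC)c2/C=C/C(=O)c2cc3ccc(C)cc3oc2=O)cc1` differs from compound 1 by methyl in place of chloro on an aromatic carbon. Among the compounds with values here, no measured step between compounds that differ in one place is at hand, so the size of this change is unknown; the expected step is a number no higher from compound 1 to compound 3 (the limit leaves the size open), that is, nothing beyond the scatter in either direction. Compound 3 is therefore estimated at 60000 nM, between 15000 nM and 200000 nM, most likely again only a limit.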

Compound 3, half-maximal inhibitory concentration: 58200 nM
Compound 3: middle estimate off by 1.0-fold (0.01 log units), on the high side, and the stated range covers the measured number.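

In this assay, methyl in place of chloro on this aromatic carbon gives an at least 1.0-fold lower number from compound 1 to compound 3 (0.01 log units; that floor lies within the scatter). With methyl, this position now has a measured number, whereas chloro gave only a limit. The step therefore has a floor but no upper bound, because compound 1 is held at a limit and not at a number: the limit of > 60000 nM in this assay, at which 1 of the 3 values shown sits.

From the compounds shown here alone, whether the swap of chloro for methyl changes the read-out beyond the scatter remains open. Also open, going by these compounds, is how an amine or a carboxylic acid on this aromatic carbon would read in this assay.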